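A few compounds are considered here, and "the series" means these few. Any claim that something is new, unique, unknown or untested is made for them only; others in the source may bear on it.

Measured so far in a functional assay on HeLa cells (Homo sapiens) for cytotoxicity, read by MTT assay, with a stated time of 48 h; a lower number here means a stronger inhibitor, a higher number a weaker inhibitor:
Compound 1 `COC(=O)c1c(-c2cc3ccccc3oc2=O)nn(-c2ccccc2)c1C(=O)OC` — 35000 nM
Compound 2 `COC(=O)c1c(-c2cc3ccccc3oc2=O)nn(-c2cccc(Cl)c2)c1C(=O)OC` — 76000 nM

Among the measured compounds shown here, compound 2 stands at the higher of the two numbers recorded in this assay, the weaker of the pair, with compound 1 as its only neighbour at a lower value. For the measured compounds named here, the step of a 2.2-fold higher number from compound 1 to compound 2 (0.34 log units; beyond the scatter) is the single measured change, and it concerns only the phenyl on the ring nitrogen.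

Compound 3 `COC(=O)c1c(-c2cc3ccccc3oc2=O)nn(-c2ccc(Br)cc2)c1C(=O)OC` differs from compound 2 in the same place: 4-bromophenyl in place of 3-chlorophenyl on an aromatic nitrogen. Going by the values given here, no measured step covers a swap of one halogenated phenyl for another, so the account can lean only on the step from compound 1 to compound 2, which was modest and showed that a halogen on that phenyl moves the number, but not by much. Both compound 2 and compound 3 carry a halogen there, so the expected step of a 1.1-fold lower number from compound 2 to compound 3 (0.04 log units; within the scatter) is judged to lie within the scatter, with no clear direction. Compound 3 is therefore expected to give about 70000 nM in this assay, with a plausible range from 30000 nM to 160000 nM.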

Compound 3, half-maximal inhibitory concentration: 120000 nM
Beside the measured number, compound 3's estimate is 1.7-fold (0.23 log units) below it; the range from low to high includes it.
By their numbers in this assay, from the lowest: compound 1; then compounds 2 and 3 (each within the scatter of the next).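

In this assay, 4-bromophenyl in place of 3-chlorophenyl on the aromatic nitrogen gives a 1.6-fold higher number from compound 2 to compound 3 (0.20 log units; within the scatter), so this measurement does not tell the two halogenated phenyls apart. Set against the unsubstituted phenyl, the bromo compound gives a 3.4-fold higher number from compound 1 to compound 3 (0.54 log units; beyond the scatter), the same direction as the chloro compound with a 2.2-fold higher number from compound 1 to compound 2 (0.34 log units; beyond the scatter), so both halogenated phenyls shown give a higher number than the plain phenyl, and neither goes against that, which on this evidence is a statement about these three compounds only. Nothing available explains why a halogen on this phenyl moves the number in this way.

Compound 2 and compound 3 differ in both the halogen and its place on the phenyl, so the compounds shown leave open which of the two matters, or whether either does. Also open, going by these compounds, is whether a phenyl carrying an amine, a carboxylic acid or a methoxy group on the same nitrogen would give a lower number than compound 1 does at 35000 nM, rather than a higher one.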